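Acid dissociation of compound 4 from a matched change

A few compounds are considered here, and "the series" means these few. Any claim that something is new, unique, unknown or untested is made for them only; others in the source may bear on it.

Of the compounds shown here, three have been measured in a physicochemical assay for acid dissociation. Compound 1 `CC(C)(C)c1ccc(-c2ccc3c(NCCCNCc4ccco4)ccnc3c2)cc1` gives 9.47. Compound 2 `Clc1ccc(Oc2ccc3c(NCCCNCc4ccco4)ccnc3c2)cc1` gives 9.28. Compound 3 `COc1ccc(F)cc1CNCCCNc1ccnc2cc(Oc3ccc(Cl)cc3)ccc12` gives 9.28, level with compound 2 at the digits shown. The two measured steps are a number 0.19 log units higher from compound 2 to compound 1 (within the scatter) and no change at the digits printed from compound 2 to compound 3 (within the scatter). Compound 4 `COc1ccc(F)cc1CNCCCNc1ccnc2cc(-c3ccc(C(C)(C)C)cc3)ccc12` has not yet been measured. From compound 3 it differs by 4-(tert-butyl)phenyl in place of 4-chlorophenoxy on an aromatic carbon. The same change occurs once more among the measured compounds, (4-(tert-butyl)phenyl in place of 4-chlorophenoxy on an aromatic carbon), where it gave a number 0.19 log units higher from compound 2 to compound 1 (within the scatter). The cores of the two pairs differ by 5-fluoro-2-methoxyphenyl in place of furan-2-yl on a saturated chain carbon bound to an amine nitrogen. The place is described in the same words for both occurrences. This is the same change. Compound 4 is therefore expected to show a number 0.17 log units higher from compound 3 to compound 4 (within the scatter), because the same change gave a number 0.19 log units higher from compound 2 to compound 1 (within the scatter). The estimate for compound 4 is 9.45, expected to fall between 9.15 and 9.75.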

Compound 4, acid dissociation constant: 9.47
Beside the measured number, compound 4's estimate is 0.02 log units below it; the range from low to high includes it.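

In this assay the 4-(tert-butyl)phenyl for 4-chlorophenoxy change gave a number 0.19 log units higher from compound 3 to compound 4 (within the scatter) on the second core, matching a number 0.19 log units higher from compound 2 to compound 1 (within the scatter) on the first, while the two 4-(tert-butyl)phenyl compounds showed no change at the digits printed from compound 1 to compound 4 (within the scatter) when 5-fluoro-2-methoxyphenyl took the place of furan-2-yl. This shows that the change carried across these two cores without a step beyond the scatter, but with every step inside it, it does not establish a real shift of any size or direction. No evidence bearing on this result is available.

The compounds shown leave open whether the same holds on a third core, for instance one with a carboxylic acid in place of furan-2-yl. Going by these compounds, a morpholine on the same aromatic carbon, or a longer chain between the two amine nitrogens, also remains open.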